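Chloro in place of hydrogen, weighed twice on one core

A few compounds are considered here, and "the series" means these few. Any claim that something is new, unique, unknown or untested is made for them only; others in the source may bear on it.

Measured in a functional assay on T47D cells (Homo sapiens) for cytotoxicity, read by MTT assay, with a stated time of 48 h; a lower number here means a stronger inhibitor, a higher number a weaker inhibitor:
compound 1, `O=C1CNc2nc(Nc3ccccc3)ncc2N1`: 85400 nM
compound 2, `O=C1CNc2nc(Nc3ccc(Cl)cc3)ncc2N1`: 29300 nM
compound 3, `CN1CC(=O)Nc2cnc(Nc3ccccc3)nc21`: reported only as a limit, > 100000 nM

Compound 1 and compound 2 share a core and differ in one place: chloro in place of hydrogen on an aromatic carbon. That change gave a 2.9-fold lower number from compound 1 to compound 2 (0.46 log units; beyond the scatter), so the chloro compound gave the lower number.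

Compound 3 differs from compound 1 in another place: methyl in place of hydrogen on a nitrogen on an aromatic ring in a ring. Here the outcome is an at least 1.1-fold higher number from compound 1 to compound 3 (0.06 log units; that floor lies within the scatter). The value of compound 3 is a limit of this assay, not a number, and it sits at the limit of > 100000 nM in this assay, at which 1 of the 3 values shown sits, so the true step from compound 1 to compound 3 cannot be sized from these data.

Compound 4, `CN1CC(=O)Nc2cnc(Nc3ccc(Cl)cc3)nc21`, has not yet been measured in this assay . It is built from compound 3 by chloro in place of hydrogen on an aromatic carbon, the same change that turned compound 1 into compound 2, and in the same place, on an aromatic carbon of a six-membered aromatic ring of carbon only, para to a large group.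

If that change acts as it did before, compound 4 is expected to show a step of an at least 1.6-fold lower number from compound 3 to compound 4 (0.22 log units; that floor lies within the scatter), resting on the step seen in a 2.9-fold lower number from compound 1 to compound 2 (0.46 log units; beyond the scatter). Since compound 3 gave only a limit, the starting point is uncertain, and compound 4 may itself fall at the limit. The estimate for compound 4 is 60000 nM, between 25000 nM and 150000 nM.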

Compound 4, half-maximal inhibitory concentration: 36000 nM
Estimate against measurement, compound 4: 1.7-fold (0.22 log units) above, within the range that was stated.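

Chloro in place of hydrogen carried over to the core bearing the methyl in this assay, giving an at least 2.7-fold lower number from compound 3 to compound 4 (0.44 log units; beyond the scatter), and this step can be set beside the earlier one only as far as a floor allows: the same change on two cores in this assay, a 2.9-fold lower number (0.46 log units; beyond the scatter) from compound 1 to compound 2 and an at least 2.7-fold lower number (0.44 log units; beyond the scatter) from compound 3 to compound 4; the limit leaves it open whether they differ

Compound 3 is reported only as a limit, > 100000 nM, so the step that starts from it gives a smallest size and not a true one: the limit of > 100000 nM in this assay, at which 1 of the 4 values shown sits.

With chloro present on both cores, methyl in place of hydrogen on a nitrogen gave a 1.2-fold higher number from compound 2 to compound 4 (0.09 log units; within the scatter), so the methyl made no difference that can be told from scatter here, and two cores show only that the chloro change held on these two, not that it would hold on any other core: the same change on two cores in this assay, an at least 1.1-fold higher number (0.06 log units; that floor lies within the scatter) from compound 1 to compound 3 and a 1.2-fold higher number (0.09 log units; within the scatter) from compound 2 to compound 4; the limit leaves it open whether they differ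

The compounds shown hold only hydrogen or chloro at this place on the aromatic ring, which leaves open whether fluoro, methoxy or an amine there would follow the same course. They also leave open what a longer chain in place of the methyl on that nitrogen would do, and whether either change would behave the same way on a different core.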